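The compounds below may be only part of what the source reports. "The series", "measured", "known", "first", "only" and "open" are said of these compounds alone.

Measured so far:
compound 1, `CCCCNc1nnc(SCC(=O)N(Cc2cccc([N+](=O)[O-])c2)c2ccc(F)cc2)s1`: in an assay on isolated protein for inhibition of Amine oxidase [flavin-containing] A (Homo sapiens), read by fluorescence and Amplex Red, with a stated time of 30 min, tested at 0.1 nM (a higher number here means a stronger effect of the compound at the concentration tested, a lower number a weaker effect), compound 1 gives 11.1%.
compound 2, `CC(C)CNc1nnc(SCC(=O)N(Cc2cccc([N+](=O)[O-])c2)c2ccc(F)cc2)s1`: in this assay compound 2 gives 12.6%.

Going by the values given here, of the two numbers, the one for compound 2 is the upper one, but the gap to compound 1 lies within the usual scatter, so the two cannot be told apart. Among the compounds with values here, the only step measured so far, a number 1.5 percentage points higher from compound 1 to compound 2 (within the scatter), alters the chain on a saturated chain carbon bound to a nitrogen on an aromatic ring and stays within the scatter. Compound 3, `C=CCNc1nnc(SCC(=O)N(Cc2cccc([N+](=O)[O-])c2)c2ccc(F)cc2)s1`, is the next compound. Its change from compound 2 is vinyl in place of isopropyl on a saturated chain carbon bound to a nitrogen on an aromatic ring. This alters the same place as the measured step, which stayed within the scatter, and both measured values are small. The step of a number 0.6 percentage points lower from compound 2 to compound 3 (within the scatter) is therefore expected to stay within the scatter. Compound 3 is estimated to give 12%, with a range from 3% to 22%.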

Compound 3, a percentage reported as inhibition, at one concentration (the size of the read-out at that concentration, not a potency): 13.5%
For compound 3 the middle estimate is 1.5 percentage points below the measured one, within the range that was stated.
By their numbers in this assay, from the lowest: compounds 1, 2 and 3 (each within the scatter of the next).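

In this assay, going by these compounds alone, the new compound brings a double bond outside aromatic rings to this position for the first time, and it gives a number 0.9 percentage points higher from compound 2 to compound 3 (within the scatter) and a number 2.4 percentage points higher from compound 1 to compound 3 (within the scatter). Isobutyl, allyl and the butyl chain of compound 1 therefore cannot be told apart here, so at this concentration the read-out does not separate a saturated chain from an unsaturated one. Nothing available here offers an explanation for this result.

The compounds shown leave open whether this position would respond to a group of another kind, such as a carboxylic acid, an amine on the chain or a much longer chain. From the compounds shown here alone, each number is also a read-out at one concentration, so how potencies compare across these compounds remains open.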